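Ring sulfur removed: from compound 3 to compound 4

The source may report more compounds than this note shows. Statements on the series, on what has been measured and on what is new or still open speak of the compounds shown alone.

Measured compounds:
Compound 1, `N/C(=N\NC(=S)N1CCOCC1)c1ccccn1`, 14.7%
Compound 2, `Cc1cccc(/C(N)=N/NC(=S)N2CCSCC2)n1`, 7.3%
Compound 3, `N/C(=N\NC(=S)N1CCSCC1)c1ccccn1`, 16.3%

In a functional assay on MCF7 cells (Homo sapiens) for cytotoxicity, read by MTT assay, with a stated time of 72 h, tested at 1 uM (a lower number here means less inhibition of growth, a higher number more inhibition of growth at the concentration tested), compound 3 gives 16.3%. The nearest number is that of compound 1; the step of a number 1.6 percentage points higher from compound 1 to compound 3 (within the scatter) separates them. Compound 2 is furthest away, by the step of a number 9 percentage points higher from compound 2 to compound 3 (within the scatter). Neither gap leaves the scatter, so the three measured compounds cannot be told apart on these numbers.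

Compound 4, `N/C(=N\NC(=S)N1CCCCC1)c1ccccn1`, has not yet been measured. Compared with compound 3 it carries piperidin-1-yl in place of thiomorpholin-4-yl on a thiocarbonyl carbon. For the measured compounds named here, of the two measured steps, only the one from compound 1 to compound 3 concerns the ring on the thiocarbonyl carbon, and a number 1.6 percentage points higher from compound 1 to compound 3 (within the scatter) was within the scatter. The step from compound 2 to compound 3 changes a different part of the molecule and gives no guidance here. On this basis a step in this assay of no more than the scatter, in either direction, is expected for compound 4, that is a number 1.3 percentage points lower from compound 3 to compound 4 (within the scatter).

Compound 4 is therefore estimated at 15%, within a range from 5% to 26%.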

Compound 4, percent growth inhibition at one concentration: 15.4%
Estimate against measurement, compound 4: 0.4 percentage points below; the range from low to high includes it.
By their numbers in this assay, from the lowest: compounds 2, 1, 4 and 3 (each within the scatter of the next).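

In this assay, piperidin-1-yl on the thiocarbonyl carbon gives a number 0.9 percentage points lower from compound 3 to compound 4 (within the scatter) and a number 0.7 percentage points higher from compound 1 to compound 4 (within the scatter). The earlier compounds shown here compared only morpholin-4-yl and thiomorpholin-4-yl, both rings with a second hetero atom; this result adds a ring with no second hetero atom, and at the tested concentration it cannot be told apart from either of them. Nothing measured here bears on why these three rings read alike.

The compounds shown leave open whether a smaller ring such as pyrrolidin-1-yl, or an open-chain amine such as diethylamino, would read differently at this position. With one concentration in one cell line, they also leave open whether the three rings would still read alike at a higher concentration or in other cells.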